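A few compounds are considered here, and "the series" means these few. Any claim that something is new, unique, unknown or untested is made for them only; others in the source may bear on it.

Measured so far:
compound 1, `CCN(CC)C(=O)c1ccccc1OCC1=NCCN1`, < 100000 nM
compound 2, `CCN(CC)C(=O)c1ccccc1OCc1c[nH]cn1`, < 100000 nM
compound 3, `c1ccc(N2CCCCC2)c(NCC2=NCCN2)c1`, < 5020 nM

All three measurements in a functional assay for activation of Alpha-1D adrenergic receptor (Homo sapiens) (a lower number here means that less compound is needed, a higher number that more compound is needed for the effect), are limits rather than numbers. For compound 1 the value < 100000 nM is a limit of the assay. For compound 2 the value < 100000 nM is likewise a limit. For compound 3 the value < 5020 nM is a limit as well, at a different level. Two of the three results sit at the limit of < 100000 nM in this assay, at which 2 of the 3 values shown sit, and one sits at the limit of < 5020 nM in this assay, at which 1 of the 3 values shown sits.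

Compound 1 and compound 2 differ in one place: a group of 5 heavy atoms (3 carbon, 2 nitrogen; one five-membered aromatic ring with 2 hetero atoms) in place of a group of 5 heavy atoms (3 carbon, 2 nitrogen; one five-membered non-aromatic ring with 2 hetero atoms), on a saturated chain carbon bound to an oxygen on an aromatic ring. Since both values are limits, the step that the two limits leave unreadable from compound 1 to compound 2 cannot be read from them. The difference between the core of compound 1 and the core of compound 3 is not broken down here.

Compound 4, `c1ccc(N2CCCCC2)c(NCc2c[nH]cn2)c1`, has not been measured. It differs from compound 3 by a group of 5 heavy atoms (3 carbon, 2 nitrogen; one five-membered aromatic ring with 2 hetero atoms) in place of a group of 5 heavy atoms (3 carbon, 2 nitrogen; one five-membered non-aromatic ring with 2 hetero atoms), on a saturated chain carbon bound to a nitrogen on an aromatic ring. Going by the values given here, this is the same kind of change as the one from compound 1 to compound 2, but not the same: there the saturated chain carbon was bound to an oxygen on an aromatic ring, here it is bound to a nitrogen on an aromatic ring. Among the compounds with values here, the only measured example of this kind of change gives no readable size, so the expectation for compound 4 rests mainly on compound 3 and its limit < 5020 nM, with wide uncertainty. The step from compound 3 to compound 4 in this assay is expected to be about a step that the limit leaves unreadable from compound 3 to compound 4. Compound 4 is therefore estimated at 3000 nM, with a likely range from 400 nM to 25000 nM.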

Compound 4, half-maximal effective concentration: < 5020 nM
Compound 4: no number, only a limit; the forecaster's own chance of this, stated with the estimate: 50%; the middle value is on the limit's open side.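

In this assay compound 4 gives < 5020 nM, which is a limit and not a number. Going by these compounds alone, compound 3 also has only a limit, so no step between compound 3 and compound 4 can be read. The compounds shown leave open whether placing an aromatic five-membered ring where the non-aromatic one stood changes the concentration needed at all, whether the chain carbon is bound to an oxygen or a nitrogen.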